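Trifluoromethyl on the sulfonyl phenyl: expected binding

The compounds below may be only part of what the source reports. "The series", "measured", "known", "first", "only" and "open" are said of these compounds alone.

Of the compounds shown here, two have numbers so far. Compound 1 `Nc1ncc(-c2cncc(NS(=O)(=O)c3ccccc3)c2)cn1` and compound 2 `CS(=O)(=O)Nc1cncc(-c2cnc(N)nc2)c1` share a core and differ only at the sulfonyl sulfur. In an assay on isolated protein for binding affinity to phosphatidylinositol 4,5-bisphosphate 3-kinase catalytic subunit beta isoform (Homo sapiens) (a higher number here means weaker binding, a lower number tighter binding), compound 1 gives 360 nM, the lower of the two numbers; in this assay compound 2 gives 5200 nM. For the measured compounds named here, the single measured step, a 14-fold higher number from compound 1 to compound 2 (1.16 log units; beyond the scatter), is large and beyond the scatter.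

Compound 3 `Nc1ncc(-c2cncc(NS(=O)(=O)c3cccc(C(F)(F)F)c3)c2)cn1` keeps the phenyl on the sulfonyl sulfur of compound 1 and differs from it by trifluoromethyl in place of hydrogen on an aromatic carbon. Going by the values given here, no measured step concerns a substituent on that phenyl ring; the step from compound 1 to compound 2 exchanges the whole phenyl for methyl and bears on this only indirectly, showing that the group on the sulfonyl sulfur matters. With nothing closer to go on, the change is expected to give a step of a 1.2-fold lower number from compound 1 to compound 3 (0.08 log units; within the scatter), within the scatter. Compound 3 is therefore expected at 300 nM in this assay, with a range of 100 nM to 1000 nM.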

Compound 3, dissociation constant: 430 nM
For compound 3 the middle estimate is 1.4-fold (0.16 log units) below the measured one, and the stated range covers the measured number.
By their numbers in this assay, from the lowest: compounds 1 and 3 (each within the scatter of the next); then compound 2.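

In this assay, trifluoromethyl in place of hydrogen on an aromatic carbon of the sulfonyl phenyl gives a 1.2-fold higher number from compound 1 to compound 3 (0.08 log units; within the scatter) and so stays within the scatter. The earlier pair showed only that methyl in place of the whole phenyl gives a 14-fold higher number from compound 1 to compound 2 (1.16 log units; beyond the scatter) and left open whether the phenyl would tolerate a substituent; compound 3 shows that this ring, at this place meta to a large group, accepts trifluoromethyl with no step beyond the scatter. Nothing measured here bears on the reason for this result.

On these data alone, whether an amine or a carboxylic acid at this place would give a similar number remains open, as does the effect of any substituent elsewhere on the phenyl. How a longer alkyl chain on the sulfonyl sulfur would compare with methyl and phenyl is also unresolved.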